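Replacing Phenyl with 2,4,6-Trimethoxyphenyl in Compound 4

The compounds below may be only part of what the source reports. "The series", "measured", "known", "first", "only" and "open" are said of these compounds alone.

Of the compounds shown here, three built on a shared core have been tested in a functional assay on HepG2 cells (Homo sapiens) for cytotoxicity, read by MTT assay, with a stated time of 48 h; a lower number here means a stronger inhibitor, a higher number a weaker inhibitor. Compound 1 `CC(C)=CCC/C(C)=C/CC/C(C)=C/CC[C@@H]1[C@@]2(C)CC/C(=N\OCc3cn(-c4cccc(Br)c4)nn3)C(C)(C)[C@@H]2CC[C@@]1(C)O` gives 39800 nM. Compound 2 `COc1cc(OC)c(-n2cc(CO/N=C3\CC[C@]4(C)[C@@H](CC/C=C(\C)CC/C=C(\C)CCC=C(C)C)[C@](C)(O)CC[C@H]4C3(C)C)nn2)c(OC)c1` carries 2,4,6-trimethoxyphenyl in place of 3-bromophenyl on an aromatic nitrogen and gives 14100 nM; the change amounts to a 2.8-fold lower number from compound 1 to compound 2 (0.45 log units; beyond the scatter). Compound 3 `CC(C)=CCC/C(C)=C/CC/C(C)=C/CC[C@@H]1[C@@]2(C)C/C(=C\c3ccc(OCc4cn(-c5ccccc5)nn4)cc3)C(=O)C(C)(C)[C@@H]2CC[C@@]1(C)O` gives 126000 nM, the highest of the three numbers, separated from compound 1 by a gap beyond the scatter and from compound 2 by a wider one.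

Compound 4 `COc1cc(OC)c(-n2cc(COc3ccc(/C=C4\C[C@]5(C)[C@@H](CC/C=C(\C)CC/C=C(\C)CCC=C(C)C)[C@](C)(O)CC[C@H]5C(C)(C)C4=O)cc3)nn2)c(OC)c1` differs from compound 3 in one place: 2,4,6-trimethoxyphenyl in place of phenyl on an aromatic nitrogen. Among the measured compounds shown here, a single measured step bears on this change, the one from compound 1 to compound 2, where 2,4,6-trimethoxyphenyl also entered on an aromatic nitrogen, though there it displaced 3-bromophenyl rather than phenyl and the rest of the molecule was not the same. Because a 2.8-fold lower number from compound 1 to compound 2 (0.45 log units; beyond the scatter) was modest yet beyond the scatter, a lowering of comparable size is expected in this assay, with some allowance for the different leaving group. The expected step is a 2.5-fold lower number from compound 3 to compound 4 (0.40 log units; beyond the scatter). For compound 4 the estimate is 50000 nM, with a range from 20000 nM to 126000 nM.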

Compound 4, half-maximal inhibitory concentration: 57500 nM
Beside the measured number, compound 4's estimate is 1.2-fold (0.06 log units) below it, and the stated range covers the measured number.
By their numbers in this assay, from the lowest: compound 2; then compounds 1 and 4 (each within the scatter of the next); then compound 3.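

In this assay, the change gives a 2.2-fold lower number from compound 3 to compound 4 (0.34 log units; beyond the scatter), so 2,4,6-trimethoxyphenyl on the aromatic nitrogen again goes with a lower number, this time replacing unsubstituted phenyl rather than 3-bromophenyl. Together with a 2.8-fold lower number from compound 1 to compound 2 (0.45 log units; beyond the scatter), this gives two modest steps in the same direction, beyond the scatter, on molecules that differ elsewhere, and neither of the four compounds' listed steps goes against that direction; the earlier pair alone could not show that the lowering was not tied to the departing bromine-bearing ring or to the rest of compounds 1 and 2. No measurement shown here explains why the number falls in either pair.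

The compounds shown leave open whether all three methoxy groups are needed for this lowering, since no ring with fewer of them, or with longer ethoxy chains in their place, appears here. From the compounds shown here alone, it also remains open how a phenyl ring carrying an amine or a carboxylic acid on this triazole nitrogen would read in this assay, and whether such a group would take the number further down or back up.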